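A few compounds are considered here, and "the series" means these few. Any claim that something is new, unique, unknown or untested is made for them only; others in the source may bear on it.

Three compounds share one core and differ only in the group attached to the urea-type nitrogen. Compound 1 `CCCCCCNC(=O)/N=C(\N)NCCCc1sc(N)nc1C` carries a simple saturated chain there; compound 2 `Cc1nc(N)sc1CCCN/C(N)=N/C(=O)NC(C)c1ccc(OC(F)(F)F)cc1` and compound 3 `Cc1ccc(C(C)NC(=O)/N=C(\N)NCCCc2sc(N)nc2C)cc1` carry a branched carbon bearing an aromatic ring. In an assay on membranes from Sf9 cells for displacement of a labelled ligand from histamine H2 receptor (Homo sapiens), read by scintillation counting, with a stated time of 60 min (a higher number here means a weaker inhibitor, a lower number a stronger inhibitor), compound 1 gives 28.8 nM, compound 2 gives 126 nM, and compound 3 gives 30.9 nM. Compound 3 thus sits second highest of the three numbers; its nearest neighbour is compound 1, and the two lie within the usual scatter of each other, so no order can be read between them. Compound 2 is clearly apart: the step of a 4.1-fold lower number from compound 2 to compound 3 (0.61 log units; beyond the scatter) shows that exchanging one substituent on the aromatic ring shifted the number by a modest but real amount.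

Compound 4 `Cc1nc(N)sc1CCCN/C(N)=N/C(=O)NC(C)c1ccco1` takes the next step from compound 3: furan-2-yl in place of 4-methylphenyl on a saturated chain carbon bound to an amide-type nitrogen and a saturated chain carbon. Among the measured compounds shown here, the only measured step that touches this part of the molecule is the exchange of ring substituents in a 4.1-fold lower number from compound 2 to compound 3 (0.61 log units; beyond the scatter); it shows the ring region can move the number modestly, but no measured pair exchanges the ring itself. Compound 4 is therefore expected to stay near compound 3, with a 1.5-fold higher number from compound 3 to compound 4 (0.16 log units; within the scatter) as the estimated step, giving an estimate of 45 nM within 15 nM to 150 nM in this assay.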

Compound 4, inhibition constant: 31.6 nM
Beside the measured number, compound 4's estimate is 1.4-fold (0.15 log units) above it, within the range that was stated.
By their numbers in this assay, from the lowest: compounds 1, 3 and 4 (each within the scatter of the next); then compound 2.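

In this assay, among the compounds shown here, the step of a 1.0-fold higher number from compound 3 to compound 4 (0.01 log units; within the scatter) is the first measured exchange of the ring itself at this position, and it puts furan-2-yl, a five-membered aromatic ring with one oxygen, level with 4-methylphenyl, a six-membered ring of carbon only, within the scatter. The step of a 1.1-fold higher number from compound 1 to compound 4 (0.04 log units; within the scatter) adds that a group with this smaller ring also cannot be told apart from the plain hexyl chain, so among compounds 1, 3 and 4 quite different groups on the amide-type nitrogen give matching numbers, while compound 2, at 126 nM, is the one that goes against this pattern. Nothing measured here bears on why these groups match.

It remains open whether the match would hold for a group carrying an amine or a carboxylic acid at this position, since every group shown has no charge. A longer chain in place of hexyl, and a substituent on the furan-2-yl ring like the one that separates compound 2 from compound 3, are equally untested by the compounds shown here.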